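A few compounds are considered here, and "the series" means these few. Any claim that something is new, unique, unknown or untested is made for them only; others in the source may bear on it.

Measured compounds:
Compound 1 `COc1cc(NC(C)CCCNC(=O)NNC(=O)/C=C/c2ccccc2)c2ncccc2c1`: 13900 nM
Compound 2 `COc1ccc(/C=C/C(=O)NNC(=O)NCCCC(C)Nc2cc(OC)cc3cccnc23)cc1`: 3600 nM

Going by the values given here, in an ADME assay on L6 cells (Rattus norvegicus) for cytotoxicity, read by resazurin assay, with a stated time of 70 h (a lower number here means a stronger inhibitor, a higher number a weaker inhibitor), compound 2 gives 3600 nM, the lowest of the two numbers so far. Among the compounds with values here, the only measured step, a 3.9-fold lower number from compound 1 to compound 2 (0.59 log units; beyond the scatter), came from adding a methoxy to an aromatic carbon. Compound 3 `COc1cc(NC(C)CCCNC(=O)NNC(=O)/C=C/c2ccc(OC)c(OC)c2)c2ncccc2c1` repeats that kind of change: methoxy in place of hydrogen on an aromatic carbon, placed ortho to a methoxy group and meta to a large group. On these data alone, whether a second methoxy lowers the number again is unknown from these two compounds alone, so a small lowering or none beyond the scatter is expected, as a 1.4-fold lower number from compound 2 to compound 3 (0.16 log units; within the scatter). Compound 3 is therefore estimated at 2500 nM, between 800 nM and 8000 nM.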

Compound 3, half-maximal inhibitory concentration: 37000 nM
Compound 3: the middle estimate sits 15-fold (1.17 log units) below what was measured, outside the stated range (above it).
By their numbers in this assay, from the lowest: compound 2; then compound 1; then compound 3.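

In this assay, adding a methoxy to this ring does not always move the number the same way: the second one, placed ortho to a methoxy group, gives a 10-fold higher number from compound 2 to compound 3 (1.01 log units; beyond the scatter) instead of a further drop. This rise outweighs the earlier drop, so 3,4-dimethoxyphenyl in place of phenyl leaves a 2.7-fold higher number from compound 1 to compound 3 (0.43 log units; beyond the scatter) overall. Nothing available explains this reversal.

Still open, on these data alone, is whether a methoxy at this place raises the number without the other methoxy on the ring. As far as these compounds go, whether a hydroxyl or a chlorine there would do the same is also open.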